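Agonist efficacy at alpha4/beta2: a ketone-to-amide step

This account rests on a few compounds, and the source may have more. Where it says the series, first, only, none or still open, it means among the compounds named here.

Measured so far:
compound 1, `C[C@H]1C[C@H]1C(=O)N1CC2CNCC2C1`, 100%
compound 2, `O=C(c1ccco1)[C@H]1C[C@@H]2CNC[C@@H](C2)C1`, "not determined" (no result reported)

For the measured compounds named here, compound 1, `C[C@H]1C[C@H]1C(=O)N1CC2CNCC2C1`, is the only member of the series with a number in an assay on SHEP1 cells for agonist activity at Neuronal acetylcholine receptor; alpha4/beta2 (Homo sapiens), read by FLIPR and calcium flux; on this read-out lower numbers stand for smaller maximal responses and higher numbers for larger maximal responses; compound 1 reaches 100%. Compound 2, `O=C(c1ccco1)[C@H]1C[C@@H]2CNC[C@@H](C2)C1`, carries a different core and has no result in this assay: for compound 2 the read-out is recorded as "not determined" (no result reported), so compound 2 stands on no number at all, and nothing can be said about how it compares with compound 1.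

Compound 3, `CCCNC(=O)[C@H]1C[C@@H]2CNC[C@@H](C2)C1`, keeps the core of compound 2 and differs from it in one place: propylamino in place of furan-2-yl on a carbonyl carbon. The carbonyl thus changes from a ketone bearing an aromatic ring to a secondary amide bearing a three-carbon chain. Going by the values given here, with no value for compound 2, no step from compound 2 to compound 3 can be computed in this assay, and no direction can be inferred from a measured pair; the only anchor is compound 1, an amide on another core that gives a full response.

On that basis the maximal response of compound 3 in this assay is expected near 60%, within roughly 15% to 110%.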

Compound 3, largest response reached (Emax), in percent of the reference or control that the assay uses: 54%
For compound 3 the middle estimate is 6 percentage points above the measured one; the range from low to high includes it.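

For the compounds shown here, compound 2 carries no number in this assay, so no step from it to compound 3 can be read. The compounds shown leave open how propylamino in place of furan-2-yl on the carbonyl carbon shifts the maximal response on this core. Nothing at hand offers an explanation for the result of compound 3.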